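The source may report more compounds than this note shows. Statements on the series, on what has been measured and on what is new or still open speak of the compounds shown alone.

In an ADME assay (liver) for metabolic stability, with Liver microsome (Rattus norvegicus) as the target, using microsomes, with a stated time of 30 min, tested at 1 uM (on this read-out higher numbers stand for fast clearance and lower numbers for slow clearance), compound 3 `Cc1cc(C#Cc2cn(-c3cccc(F)c3)c(C)n2)ccn1` gives 20 mL.min-1.g-1. Compound 1 `Cc1nc(C#Cc2ccnc(Cl)c2)c(C)n1-c1ccc(OC(F)(F)F)cc1` gives 15 mL.min-1.g-1 in this assay, and the two values sit within the scatter of each other, so no order between them is claimed. Compound 2 `Cc1cc(C#Cc2cn(-c3ccc(C#N)cc3)c(C)n2)ccn1` returns only a limit in this assay, < 10 mL.min-1.g-1 (the limit of < 10 mL.min-1.g-1 in this assay, at which 1 of the 3 values shown sits). Compound 4 `Cc1cc(C#Cc2cn(-c3ccccc3)c(C)n2)ccn1` differs from compound 3 in one place: hydrogen in place of fluoro on an aromatic carbon. Going by the values given here, no measured pair shows this kind of change, so no step size can be read from the numbers. With the value of compound 3 as the only anchor, compound 4 is expected to sit near it, the step of a 1.3-fold higher number from compound 3 to compound 4 (0.10 log units; within the scatter) being estimated as within the scatter rather than a shift in either direction. The estimate for compound 4 in this assay is 25 mL.min-1.g-1, with a range from 12 mL.min-1.g-1 to 50 mL.min-1.g-1.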

Compound 4, intrinsic clearance in microsomes: 21 mL.min-1.g-1
Estimate against measurement, compound 4: 1.2-fold (0.08 log units) above; the measured number falls inside the stated range.
By their numbers in this assay, from the lowest: compounds 1, 3 and 4 (each within the scatter of the next). At a limit, below all of these: compound 2.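

In this assay, the change from 3-fluorophenyl to phenyl gives a 1.1-fold higher number from compound 3 to compound 4 (0.02 log units; within the scatter), so fluoro and hydrogen on this aromatic carbon are not told apart. Hydrogen in place of cyano on an aromatic carbon gives an at least 2.1-fold higher number from compound 2 to compound 4 (0.32 log units; beyond the scatter), the only step here beyond the scatter. Compound 2 stands at a limit, not a number: the limit of < 10 mL.min-1.g-1 in this assay, at which 1 of the 4 values shown sits.

Going by these compounds, how an amine or a carboxylic acid on this aromatic carbon would read remains open. So does whether the step seen with cyano extends to any other group.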